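Cytotoxicity of a bromoquinoline triazole series: compound 4

A few compounds are considered here, and "the series" means these few. Any claim that something is new, unique, unknown or untested is made for them only; others in the source may bear on it.

Measured compounds:
Compound 1, `CCCc1cn(C(c2ccccc2)c2cc3cc(Br)ccc3nc2OC)nn1`, gives -2.25% in an ADME assay on HeLa cells (Homo sapiens) for cytotoxicity, read by sulforhodamine B assay, with a stated time of 48 h, tested at 10 uM; on this read-out higher numbers stand for more inhibition at the one concentration tested (going by the name of the read-out) and lower numbers for less inhibition.
Compound 2, `COc1nc2ccc(Br)cc2cc1C(c1ccccc1)n1cc(-c2ccc(OC(F)(F)F)cc2)nn1`, gives -2.24% in this assay.
Compound 3, `COc1nc2ccc(Br)cc2cc1C(c1ccccc1)n1cc(CCO)nn1`, gives 0.85% in this assay.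

All three numbers lie close together. Compound 3 sits at the upper end of the three, but the steps of a number 3.1 percentage points higher from compound 1 to compound 3 (within the scatter) and a number 3.1 percentage points higher from compound 2 to compound 3 (within the scatter) are both within the scatter, so nothing separates it from compound 1 or compound 2 on this read-out.

Compound 4, `COc1nc2ccc(Br)cc2cc1C(c1ccccc1)n1cc(-c2cccc(F)c2)nn1`, has not yet been measured. It differs from compound 3 in one place: 3-fluorophenyl in place of 2-hydroxyethyl on an aromatic carbon.

Among the compounds with values here, two measured steps bear on this change. The step of a number 0 percentage points higher from compound 1 to compound 2 (within the scatter) swapped a chain for an aromatic ring on the same position and moved nothing. The step of a number 3.1 percentage points higher from compound 2 to compound 3 (within the scatter) runs in the opposite sense to the change now made and also stayed within the scatter. On these steps no movement beyond the scatter is expected in this assay, and the step of a number 1.9 percentage points lower from compound 3 to compound 4 (within the scatter) is estimated to be small.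

Compound 4 is therefore expected to give about -1%, within a range from -10% to 8%.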

Compound 4, a percentage reported as inhibition, at one concentration (the size of the read-out at that concentration, not a potency): 9.04%
Compound 4: the middle estimate sits 10 percentage points below what was measured, and the stated range ends below it.
By their numbers in this assay, from the lowest: compounds 1, 2, 3 and 4 (each within the scatter of the next, the first and the last beyond it).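

Within the data shown here, at this aromatic carbon of the five-membered ring, the choice of group can register in this assay: 3-fluorophenyl gives a number 11.3 percentage points higher from compound 2 to compound 4 (beyond the scatter) and a number 11.3 percentage points higher from compound 1 to compound 4 (beyond the scatter), the first steps at this place to pass the scatter. An aromatic ring alone does not account for this, as compound 2 also carries one at this place, while the change from 2-hydroxyethyl gives only a number 8.2 percentage points higher from compound 3 to compound 4 (within the scatter) and leaves compound 3 and compound 4 unseparated. Nothing available explains why 3-fluorophenyl and 4-(trifluoromethoxy)phenyl part here.

The compounds shown leave open whether the ring or its fluorine goes with the higher number, which a plain phenyl would help to test. They also leave open how an amine or a carboxylic acid at this place would read.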